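This account rests on a few compounds, and the source may have more. Where it says the series, first, only, none or still open, it means among the compounds named here.

Compound 1 `COc1cc(-c2nnc(SCC(=O)c3cccc(Br)c3)n2N)cc(OC)c1OC`: 56000 nM
Compound 2 `COc1cc(-c2nnc(SCC(=O)c3ccc(F)c(F)c3)n2N)cc(OC)c1OC`: > 100000 nM

In a functional assay on HepG2 cells (Homo sapiens) for antiproliferative activity, read by MTT assay, with a stated time of 48 h (a higher number here means a weaker inhibitor, a lower number a stronger inhibitor), compound 1 gives 56000 nM. For compound 2 the result is only a limit, > 100000 nM, so no exact number is known (the limit of > 100000 nM in this assay, at which 1 of the 2 values shown sits). Within the data shown here, the one measured step, an at least 1.7-fold higher number from compound 1 to compound 2 (0.25 log units; that floor lies within the scatter), runs toward this limit. Compound 3 `COc1cc(-c2nnc(SCC(=O)c3ccccc3F)n2N)cc(OC)c1OC` differs from compound 2 in one place: 2-fluorophenyl in place of 3,4-difluorophenyl on a carbonyl carbon. Among the measured compounds shown here, the only step that bears on this change is the move from compound 1 to compound 2, and its floor lies within the scatter, so it gives little direction. With compound 2 already at the limit, the step of an at least 1.2-fold lower number from compound 2 to compound 3 (0.09 log units; that floor lies within the scatter) is expected to be small, and a further limit is about as likely as a number. Compound 3 is therefore estimated at 80000 nM in this assay, within 30000 nM to 250000 nM.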

Compound 3, half-maximal inhibitory concentration: 22600 nM
Beside the measured number, compound 3's estimate is 3.5-fold (0.55 log units) above it; measured number below the stated range.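

Changing the aryl group on the carbonyl carbon clearly shifts the result in this assay: the earlier step had only a floor within the scatter, whereas this one shows an at least 4.4-fold lower number from compound 2 to compound 3 (0.64 log units; beyond the scatter). The 2-fluorophenyl group also compares well with the 3-bromophenyl group, with a 2.5-fold lower number from compound 1 to compound 3 (0.39 log units; beyond the scatter), which makes compound 3 the strongest of the three, with both of its steps beyond the scatter. Compound 2 is a limit and not a number, so the step from it gives only a floor: the limit of > 100000 nM in this assay, at which 1 of the 3 values shown sits.

The 3,4-difluorophenyl and 2-fluorophenyl groups differ in both the number of fluorines and where they sit, and the compounds shown do not separate these two changes. They also leave open how a plain phenyl, or a phenyl carrying an amine or a carboxylic acid, would behave at this place.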